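The source may report more compounds than this note shows. Statements on the series, on what has been measured and on what is new or still open speak of the compounds shown alone.

Working notes on the series. Going by the values given here, the shared core of compound 1 `Cn1nc2c(=O)n(CC3(O)CCN(Cc4ccc(-c5ccco5)cc4Cl)CC3)cnc2c1-c1ccc(C(F)(F)F)cc1` carries a trifluoromethyl group on its terminal aryl ring; in an assay on isolated protein for inhibition of ubiquitin carboxyl-terminal hydrolase 7 (Homo sapiens), with stated times of 30 min and 2 h (on this read-out lower numbers stand for stronger inhibition and higher numbers for weaker inhibition), compound 1 gives 530 nM, the highest of the three numbers so far. Compound 2 `Cn1nc2c(=O)n(CC3(O)CCN(Cc4ccc(-c5ccoc5)cc4Cl)CC3)cnc2c1-c1ccc(CN)cc1` gives 177 nM and compound 3 `Cn1nc2c(=O)n(CC3(O)CCN(Cc4ccc(C5=CCCC5)cc4Cl)CC3)cnc2c1-c1ccc(CN)cc1` gives 76.9 nM. Among the compounds with values here, the only single-point step measured, a 2.3-fold lower number from compound 2 to compound 3 (0.36 log units; beyond the scatter), concerns the other end of the molecule and does not bear on the change considered here. Compound 4 `Cn1nc2c(=O)n(CC3(O)CCN(Cc4ccc(-c5ccco5)cc4Cl)CC3)cnc2c1-c1ccc(CNC2CC2)cc1` differs from compound 1 by (cyclopropylamino)methyl in place of trifluoromethyl on an aromatic carbon. Within the data shown here, compound 1 and compound 2 differ in more than one place, so no step connects them directly; still, where compound 1 carries trifluoromethyl and gives 530 nM, compound 2 carries an aminomethyl group and shows the lower number of the two, 177 nM. On that basis a modest lowering, a 2.4-fold lower number from compound 1 to compound 4 (0.38 log units; beyond the scatter), is expected, though with little support. Compound 4 is estimated at 220 nM, with a range of 80 nM to 600 nM.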

Compound 4, half-maximal inhibitory concentration: 54.1 nM
For compound 4 the middle estimate is 4.1-fold (0.61 log units) above the measured one; the whole stated range lies above it.
By their numbers in this assay, from the lowest: compounds 4 and 3 (each within the scatter of the next); then compound 2; then compound 1.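

In this assay, going by these compounds alone, a 9.8-fold lower number from compound 1 to compound 4 (0.99 log units; beyond the scatter) gives the first direct reading at this position, an aromatic carbon para to a large group, with the rest of the molecule unchanged. Trifluoromethyl, which has no ring and no hydrogen-bond donor or acceptor, leaves; (cyclopropylamino)methyl enters, bringing a nitrogen, a hydrogen-bond donor and acceptor, and a three-membered ring of carbon only, and the lower number goes with this exchange. No measurement shown here explains the step or ties it to any one of these features.

The compounds shown contain no pair that separates the contribution of the nitrogen from that of the cyclopropyl ring, since none compares (cyclopropylamino)methyl with aminomethyl on an otherwise identical molecule. On these data alone, how a dimethylamino group, a carboxylic acid or a longer chain would read at this position remains open.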